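The compounds below may be only part of what the source reports. "The series", "measured", "known", "first", "only" and "open" are said of these compounds alone.

Compound 1 `C[C@@H](NC(=O)Nc1ccc(C(C)(C)C)cc1)c1ccccc1`: in an ADME assay on the whole organism with Oryza sativa as the target, tested at 0.1 uM (on this read-out lower numbers stand for a stronger effect and higher numbers for a weaker effect at the one concentration tested), compound 1 gives 100%.
Compound 2 `C[C@H](NC(=O)Nc1ccc(C(C)(C)C)cc1)c1ccccc1`: in this assay compound 2 gives 100%.
Compound 3 `C[C@H](NC(=O)Nc1cccc(Br)c1)c1ccccc1`: in this assay compound 3 gives 100%.

Compound 1 sits level with compounds 2 and 3, all three at the same reading. Within the data shown here, the only measured step, no change at the digits printed from compound 1 to compound 2 (within the scatter), was flat, which fits (the fact that compounds 1 and 2 differ only in the configuration as drawn). Compound 4 `C[C@@H](NC(=O)Nc1ccc(I)cc1)c1ccccc1` differs from compound 1 in one place: iodo in place of tert-butyl on an aromatic carbon. Among the measured compounds shown here, no measured step covers a change of a substituent on that ring, so the configuration step gives no guide here; compound 3, which carries a bromo, simply reads the same as compound 1. The step expected from compound 1 is therefore no change at the digits printed from compound 1 to compound 4 (within the scatter), nothing beyond the scatter. Compound 4 is expected to give 100%, estimated between 85% and 100%.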

Compound 4, a percentage reported as activity, at one concentration (the size of the read-out at that concentration, not a potency): 100%
Estimate against measurement, compound 4: no gap at the digits printed; the range from low to high includes it.
By their numbers in this assay, from the lowest: compounds 1, 2, 3 and 4 (each within the scatter of the next).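

Replacing tert-butyl, with 4 heavy atoms, by iodo, with 1 heavy atom, on this aromatic carbon gives no change at the digits printed from compound 1 to compound 4 (within the scatter) in this assay. Among these compounds, the only earlier step was a change of configuration, so this is the first sign that the reading can also stay flat when the substituent itself changes. Nothing available explains this flat step.

From the compounds shown here alone, it remains open whether an amine or a carboxylic acid at this position would move the reading. With all four compounds level, it is also unclear which parts of the structure, if any, affect this read-out.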